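Methoxy in place of propyl on the benzamide of compound 2

The source may hold more compounds than are shown below. What is called first, only, known or untested is meant among the compounds shown, and "the series" means these compounds.

Measured in an assay on isolated protein for inhibition of Rho-associated protein kinase 2 (Homo sapiens), read by scintillation counting, radiometric assay and 33P incorporation, with a stated time of 40 min, in the presence of a further agent that is not named here; a higher number here means a weaker inhibitor, a lower number a stronger inhibitor:
compound 1 `Cc1ccc(C(=O)Nc2cccc(NC(=O)COc3ccc4c(=O)ccoc4c3)c2)cc1`: 22 nM
compound 2 `CCCc1ccc(C(=O)Nc2cccc(NC(=O)COc3ccc4c(=O)ccoc4c3)c2)cc1`: 14 nM

Among the compounds with values here, compound 2 holds the lower of the two numbers; its only neighbour is compound 1, and the step of a 1.6-fold lower number from compound 1 to compound 2 (0.20 log units; within the scatter) lies within the scatter, so the two cannot be ranked. Compound 3 `COc1ccc(C(=O)Nc2cccc(NC(=O)COc3ccc4c(=O)ccoc4c3)c2)cc1` is not yet measured. It differs from compound 2 by methoxy in place of propyl on an aromatic carbon. Within the data shown here, the single measured step, a 1.6-fold lower number from compound 1 to compound 2 (0.20 log units; within the scatter), bears on this position but concerns a longer alkyl chain, not an oxygen-bearing group, and it was small. There is thus no basis for expecting a step beyond the scatter in this assay in either direction. The estimate for compound 3 is 20 nM, with a range of 8 nM to 50 nM. This estimate corresponds to an expected step of a 1.4-fold higher number from compound 2 to compound 3 (0.15 log units; within the scatter).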

Compound 3, half-maximal inhibitory concentration: 7 nM
For compound 3 the middle estimate is 2.9-fold (0.46 log units) above the measured one, outside the stated range (below it).
By their numbers in this assay, from the lowest: compounds 3, 2 and 1 (each within the scatter of the next, the first and the last beyond it).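

In this assay, methoxy in place of propyl gives a 2.0-fold lower number from compound 2 to compound 3 (0.30 log units; within the scatter), so an oxygen-linked group at this aromatic carbon cannot be ranked against the propyl chain, and no alkyl chain is needed here to keep the number at this level. Methoxy in place of methyl gives a 3.1-fold lower number from compound 1 to compound 3 (0.50 log units; beyond the scatter), the first step at this position to clear the scatter, though only a modest one. No measurement bears on the reason for either step.

Still open, as far as these compounds go, is whether the step from methyl to methoxy carries over to other oxygen-linked groups, such as ethoxy or a hydroxyl. Also open, from the compounds shown here alone, is how an amine or a carboxylic acid on this carbon would read, and whether methoxy would behave the same way elsewhere on this ring.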